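This account rests on a few compounds, and the source may have more. Where it says the series, first, only, none or still open, it means among the compounds named here.

Compound 1 `Cn1nc2c(=O)n(CC3(O)CCN(Cc4ccc(-c5n[nH]c(=O)o5)cc4Cl)CC3)cnc2c1-c1ccc(CN)cc1` gives 171 nM in an assay on isolated protein for inhibition of ubiquitin carboxyl-terminal hydrolase 7 (Homo sapiens), with stated times of 30 min and 2 h; a higher number here means a weaker inhibitor, a lower number a stronger inhibitor.
Compound 2 `Cn1nc2c(=O)n(CC3(O)CCN(Cc4ccc(-c5cnco5)cc4Cl)CC3)cnc2c1-c1ccc(CN)cc1` gives 71.6 nM in this assay.
Compound 3 `Cn1nc2c(=O)n(CC3(O)CCN(Cc4ccc(C5CCCO5)cc4Cl)CC3)cnc2c1-c1ccc(CN)cc1` gives 3820 nM in this assay.

Compound 3 stands highest of the three numbers and is the weakest inhibitor among them, since the steps of a 22-fold higher number from compound 1 to compound 3 (1.35 log units; beyond the scatter) and a 53-fold higher number from compound 2 to compound 3 (1.73 log units; beyond the scatter) both lie well beyond the scatter. Compound 4 `Cn1cc(-c2ccc(CN3CCC(O)(Cn4cnc5c(-c6ccc(CN)cc6)n(C)nc5c4=O)CC3)c(Cl)c2)cn1` has not yet been measured. It differs from compound 3 in one place: 1-methyl-1H-pyrazol-4-yl in place of oxolan-2-yl on an aromatic carbon. The group that leaves is one five-membered non-aromatic ring with 1 hetero atom; the group that enters is one five-membered aromatic ring with 2 hetero atoms, and it sits on the same aromatic carbon.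

Going by the values given here, two measured steps bear on this change. In compound 1 and compound 2 that aromatic carbon also carries a five-membered aromatic ring with hetero atoms, and going from either of them to the non-aromatic oxolan-2-yl of compound 3 raised the number a great deal, as a 22-fold higher number from compound 1 to compound 3 (1.35 log units; beyond the scatter) and a 53-fold higher number from compound 2 to compound 3 (1.73 log units; beyond the scatter) show. The change from compound 3 to compound 4 runs the other way, from the non-aromatic ring back to an aromatic one. A large downward step is therefore expected, roughly a 35-fold lower number from compound 3 to compound 4 (1.54 log units; beyond the scatter), giving an estimated value for compound 4 of 110 nM, with a range from 30 nM to 450 nM.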

Compound 4, half-maximal inhibitory concentration: 291 nM
For compound 4 the middle estimate is 2.6-fold (0.42 log units) below the measured one; low and high end bracket the measured number.
By their numbers in this assay, from the lowest: compound 2; then compounds 1 and 4 (each within the scatter of the next); then compound 3.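

A third five-membered aromatic ring on this aromatic carbon, 1-methyl-1H-pyrazol-4-yl, also gives a far lower number than oxolan-2-yl in this assay (a 13-fold lower number from compound 3 to compound 4 (1.12 log units; beyond the scatter)), so all three aromatic rings shown outperform the one non-aromatic ring, and no compound here goes against that. The aromatic rings are not interchangeable, however: 1,3-oxazol-5-yl remains clearly better than 1-methyl-1H-pyrazol-4-yl (a 4.1-fold higher number from compound 2 to compound 4 (0.61 log units; beyond the scatter)), whereas compound 4 cannot be separated from compound 1 (a 1.7-fold higher number from compound 1 to compound 4 (0.23 log units; within the scatter)), whose ring has a different set of hetero atoms. No measurement on hand explains these differences.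

With only one non-aromatic ring shown, the compounds leave open whether the aromatic character of the ring itself is what matters, and a piperidine or morpholine ring, a six-membered aromatic ring such as phenyl or pyridyl, or an open chain such as an amine or a carboxylic acid on this carbon could help to settle that. They also leave open what the methyl group on the pyrazole contributes, a question that the pyrazol-4-yl ring without that methyl or with an ethyl group in its place could answer.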